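The source may report more compounds than this note shows. Statements on the series, on what has been measured and on what is new or still open speak of the compounds shown alone.

Three related bases have been measured in an assay on CHO cells for displacement of a labelled ligand from C-X-C chemokine receptor type 4 (Homo sapiens), with a stated time of 40 min; on this read-out lower numbers stand for stronger inhibition and higher numbers for weaker inhibition. Compound 1 `c1c(CNCCCNC2CCCCC2)cc(CNCCCNC2CCCCC2)cc1CNCCCNC1CCCCC1` gives 312 nM in this assay. Compound 2 `Nc1cc(CNCCCNC2CCCCC2)cc(CNCCCNC2CCCCC2)c1` gives 81.2 nM in this assay, and compound 3 `CNc1cc(CNCCCNC2CCCCC2)cc(CNCCCNC2CCCCC2)c1` gives 67.6 nM. The steps of a 3.8-fold lower number from compound 1 to compound 2 (0.58 log units; beyond the scatter) and a 4.6-fold lower number from compound 1 to compound 3 (0.66 log units; beyond the scatter) both lie beyond the scatter, whereas the step of a 1.2-fold lower number from compound 2 to compound 3 (0.08 log units; within the scatter) does not. Compound 3 therefore carries the lowest of the three numbers, but it is set apart only from compound 1, not from compound 2.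

Compound 4 `CN(C)c1cc(CNCCCNC2CCCCC2)cc(CNCCCNC2CCCCC2)c1` is the next member of the set. Its change from compound 3 is methyl in place of hydrogen on a nitrogen on an aromatic ring: a hydrogen leaves and a methyl enters on that nitrogen, and read one bond further out the change is methylamino to dimethylamino. Within the data shown here, the single measured step that bears on this change is the earlier addition of a methyl on the same nitrogen, a 1.2-fold lower number from compound 2 to compound 3 (0.08 log units; within the scatter), which stayed within the scatter. On that basis no step beyond the scatter is expected in this assay in either direction, and the estimated step is a 1.0-fold higher number from compound 3 to compound 4 (0.02 log units; within the scatter). Compound 4 is expected to give about 70 nM in this assay, with a range from 35 nM to 140 nM.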

Compound 4, half-maximal inhibitory concentration: 119 nM
Estimate against measurement, compound 4: 1.7-fold (0.23 log units) below; measured number inside the range.
By their numbers in this assay, from the lowest: compounds 3, 2 and 4 (each within the scatter of the next); then compound 1.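

A second methyl on the nitrogen on an aromatic ring again stays inside the scatter in this assay (a 1.8-fold higher number from compound 3 to compound 4 (0.25 log units; within the scatter)), and the two methyls taken together do the same (a 1.5-fold higher number from compound 2 to compound 4 (0.17 log units; within the scatter)), so amino, methylamino and dimethylamino cannot be told apart at this position on these numbers. Dimethylamino in place of ((3-(cyclohexylamino)propyl)amino)methyl on an aromatic carbon still gives a step beyond the scatter (a 2.6-fold lower number from compound 1 to compound 4 (0.42 log units; beyond the scatter)), so all three small nitrogen groups now stand apart from compound 1, and that separation does not depend on how many methyls the nitrogen carries. Nothing at hand explains why these steps have the sizes they have.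

Still open, on these data alone, is whether a larger group on this nitrogen, such as an ethyl or an acetyl, would move the number beyond the scatter. Also open, as far as these compounds go, is how a group without a nitrogen at this place, such as a hydroxyl or a carboxylic acid, would compare with the amino group of compound 2.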